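From butyl to tert-butyl on the shared core

A few compounds are considered here, and "the series" means these few. Any claim that something is new, unique, unknown or untested is made for them only; others in the source may bear on it.

Measured so far:
compound 1 `CCc1nc2c(OCc3ccccc3)cccn2c1N` gives 83%
compound 2 `CCCc1nc2c(OCc3ccccc3)cccn2c1N` gives 31%
compound 3 `CCCCc1nc2c(OCc3ccccc3)cccn2c1N` gives 26%

All three compounds were tested in a functional assay on the whole organism with Rattus norvegicus as the target, at a dose of 40 mg/kg by the intraperitoneal route; a higher number here means more inhibition at the dose given (going by the name of the read-out), a lower number less inhibition. Compound 3 has the lowest number of the three. Its nearest neighbour is compound 2, and the step of a number 5 percentage points lower from compound 2 to compound 3 (within the scatter). Compound 1 stands furthest from it: a number 57 percentage points lower from compound 1 to compound 3 (beyond the scatter). The other step that leaves compound 1 is similar in kind: a number 52 percentage points lower from compound 1 to compound 2 (beyond the scatter).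

The next compound is compound 4 `CC(C)(C)c1nc2c(OCc3ccccc3)cccn2c1N`, which has not yet been measured in this assay. Compared with compound 3 the change is tert-butyl in place of butyl on an aromatic carbon; the two have the same atoms, joined differently.

The two large steps seen so far both start from compound 1 and lengthen the chain, while the step from compound 2 to compound 3 adds one carbon along the chain and stays within the scatter. Going by the values given here, none of the measured steps rearranges a chain without changing its atoms, so there is no direct precedent for this change. On the steps that exist, the closest guide is the small step from compound 2 to compound 3, and compound 4 is therefore expected to show a step of a number 4 percentage points higher from compound 3 to compound 4 (within the scatter) that stays within the scatter. Compound 4 is estimated at 30%, with a range from 10% to 55%.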

Compound 4, a percentage reported as inhibition, in the whole organism at one dose (the size of the read-out at that dose, not a potency): 0%
Estimate against measurement, compound 4: 30 percentage points above, outside the stated range (below it).
By their numbers in this assay, from the lowest: compound 4; then compounds 3 and 2 (each within the scatter of the next); then compound 1.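

In this assay, the way the chain is joined matters on this aromatic carbon, and not only its size: butyl and tert-butyl have the same atoms, yet the change gives a number 26 percentage points lower from compound 3 to compound 4 (beyond the scatter). Until now, the only clear split lay between ethyl and the two longer straight chains, but tert-butyl falls beyond that group, with a number 31 percentage points lower from compound 2 to compound 4 (beyond the scatter) and a number 83 percentage points lower from compound 1 to compound 4 (beyond the scatter), so that compound 4, at 0%, has the lowest number of the four. Nothing at hand explains this fall, and the result describes only what happens to the read-out at this dose.

Going by these compounds, it remains open whether any branching at this position lowers the number or whether this is particular to tert-butyl: isopropyl, with its shorter branched chain, or cyclopropyl could fall either with compound 4 or nearer to compound 1. Equally open, on these data alone, is whether methyl, a group shorter than ethyl, would keep the high number of compound 1 on the shared core.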